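The source may report more compounds than this note shows. Statements on the series, on what has been measured and on what is new or still open speak of the compounds shown alone.

Measured compounds:
- compound 1, `Cc1cc(NNC(=O)Nc2cc(Cl)nc(Cl)c2)ncc1C#N`: in a functional assay on CHO cells for agonist activity at sphingosine 1-phosphate receptor 2 (Homo sapiens), read by fluorescence and calcium flux, with a stated time of 3 min (on this read-out lower numbers stand for stronger inhibition and higher numbers for weaker inhibition), compound 1 gives > 23000 nM.
- compound 2, `Cc1cc(CO)nc(NNC(=O)Nc2cc(Cl)nc(Cl)c2)c1`: in this assay compound 2 gives > 23000 nM.

The value of compound 1 is a limit of the assay, not a number. The value of compound 2 is likewise a limit and not a number. Within the data shown here, compound 1 therefore stands at the limit of > 23000 nM in this assay, at which 2 of the 2 values shown sit; the two values show no separation between compound 1 and compound 2, and no step between measured compounds can be drawn from them.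

Compound 3, `Cc1cc(NNC(=O)Nc2cc(Cl)nc(Cl)c2)ncc1-c1cn(C)nc1C`, is not yet measured. It differs from compound 1 by 1,3-dimethyl-1H-pyrazol-4-yl in place of cyano on an aromatic carbon, with the rest of the shared core unchanged. With both measured values resting at the limit, the data give no direction for this change. The expected step, a step that the limit leaves unreadable from compound 1 to compound 3, is none beyond the scatter, and a further limit is the most likely outcome. For compound 3 in this assay the estimate is 30000 nM, with an expected range from 4000 nM to 150000 nM.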

Compound 3, half-maximal inhibitory concentration: > 23000 nM
Compound 3: only a limit was reported; the forecaster's own chance of this, stated with the estimate: 75%; the middle value is on the limit's open side.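

In this assay compound 3 gives > 23000 nM as a limit and not a number. No new step can be read between compound 1 and compound 3 because both values are limits: the limit of > 23000 nM in this assay, at which 3 of the 3 values shown sit. The compounds shown leave open which change to the shared core, if any, would give a measurable value on this read-out.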